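The source may report more compounds than this note shows. Statements on the series, on what has been measured and on what is new or still open speak of the compounds shown alone.

The measured compounds are compound 1, `CCCCNc1nc(N)nc2ccn(CCCc3ccccc3)c12`, which in an assay on HEK293 cells for agonist activity at Toll-like receptor 8 (Homo sapiens), read by a luciferase reporter, with a stated time of 6 h (on this read-out higher numbers stand for an effect only at larger amounts of compound and lower numbers for an effect already at smaller amounts), gives 3.78 uM, and compound 2, `CCCCNc1nc(N)nc2ccn(Cc3nccs3)c12`, which in this assay gives 2.27 uM. Compound 3, `CCCCNc1nc(N)nc2ccn(Cc3ccccn3)c12`, gives in this assay only a limit, > 25 uM.

Compound 3 thus stands at the edge of what this assay can report, (the limit of > 25 uM in this assay, at which 1 of the 3 values shown sits), while the other two compounds give numbers. Compared with them it is the weak end of the set: an at least 6.6-fold higher number from compound 1 to compound 3 (0.82 log units; beyond the scatter) and an at least 11-fold higher number from compound 2 to compound 3 (1.04 log units; beyond the scatter), both beyond the scatter, whereas a 1.7-fold lower number from compound 1 to compound 2 (0.22 log units; within the scatter) is within it.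

Compound 4, `CCCCNc1nc(N)nc2ccn(Cc3ncccc3OC)c12`, differs from compound 3 by methoxy in place of hydrogen on an aromatic carbon. None of the three measured steps concerns a methoxy group; all of them exchange the whole ring on the saturated chain carbon bound to an aromatic nitrogen. So no measured step bears directly on this change, and the only anchor is that compound 3 stands at a limit. The size and direction of the step in this assay are therefore open, and a further limit is about as likely as a number. Compound 4 is expected to give about 20 uM, within a wide range of 5 uM to 60 uM, that is, an expected step of an at least 1.2-fold lower number from compound 3 to compound 4 (0.09 log units; that floor lies within the scatter).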

Compound 4, minimum effective concentration: 0.59 uM
Compound 4: middle estimate off by 34-fold (1.53 log units), on the high side, outside the stated range (below it).
By their numbers in this assay, from the lowest: compound 4; then compounds 2 and 1 (each within the scatter of the next). At a limit, above all of these: compound 3.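

The methoxy group, placed on an aromatic carbon ortho to a large group and two atoms from the ring nitrogen, changes the outcome for the pyridin-2-yl series in this assay: an at least 42-fold lower number from compound 3 to compound 4 (1.62 log units; beyond the scatter). Among the compounds shown here, the earlier compounds showed only that exchanging the whole ring could move the read-out, whereas this result shows that a substituent on the ring can do so, and that the pyridin-2-yl ring is compatible with a low number once it carries methoxy at this place. 3-Methoxypyridin-2-yl also compares well with the other two groups on the saturated chain carbon, with a 3.8-fold lower number from compound 2 to compound 4 (0.59 log units; beyond the scatter) and a 6.4-fold lower number from compound 1 to compound 4 (0.81 log units; beyond the scatter), and the size of the step from the unsubstituted ring is only a floor, since that compound gives a limit and not a number: the limit of > 25 uM in this assay, at which 1 of the 4 values shown sits.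

The compounds shown leave open whether this effect belongs to methoxy itself or would also appear with a hydroxyl, a fluorine or an ethoxy group at the same place. They also leave open whether methoxy on another carbon of that ring, or on the 1,3-thiazol-2-yl ring, would change the read-out in this assay in the same direction.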